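A few compounds are considered here, and "the series" means these few. Any claim that something is new, unique, unknown or untested is made for them only; others in the source may bear on it.

Measured so far in a functional assay on HeLa cells (Homo sapiens) for cytotoxicity, with a stated time of 72 h; a lower number here means a stronger inhibitor, a higher number a weaker inhibitor:
compound 1 `CCCC#Cc1cn([C@@H]2O[C@H](CO)[C@@H](O)[C@H](O)[C@H]2O)c(=O)[nH]c1=O` gives 95000 nM
compound 2 `CCCc1cc2cn([C@@H]3O[C@H](CO)[C@@H](O)[C@H](O)[C@H]3O)c(=O)nc2o1` gives 125000 nM
compound 3 `CCCCCc1cc2cn([C@@H]3O[C@H](CO)[C@@H](O)[C@H](O)[C@H]3O)c(=O)nc2o1` gives > 250000 nM, which is a limit of the assay and not a number

Among the two numbers, compound 1 stands lowest, with compound 2 close by; the gap between them lies within the scatter, so no order can be read from it. Compound 3 sits at the limit of > 250000 nM in this assay, at which 1 of the 3 values shown sits. For the measured compounds named here, the only step that can be followed in this assay is an at least 2.0-fold higher number from compound 2 to compound 3 (0.30 log units; that floor lies within the scatter), a change of ethyl in place of hydrogen on a saturated chain carbon, three bonds along the chain from an aromatic carbon; its floor lies within the scatter, so it shows at most a modest move toward weaker inhibition on lengthening the chain.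

Compound 4 `O=c1[nH]c(=O)n([C@@H]2O[C@H](CO)[C@@H](O)[C@H](O)[C@H]2O)cc1CCc1ccccc1` keeps the shared core of compound 1 and differs by phenethyl in place of pent-1-yn-1-yl on an aromatic carbon. Going by the values given here, no measured pair changes this group directly, and the one step in hand concerns a different core. What the data offer is weak: compounds 1 and 2 sit together, and compound 3 drifts toward the limit as its chain grows.

Compound 4 is therefore expected near compound 1, with the step of a 1.2-fold higher number from compound 1 to compound 4 (0.06 log units; within the scatter) estimated to stay within the scatter. The estimate for compound 4 in this assay is 110000 nM, between 40000 nM and 250000 nM.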

Compound 4, half-maximal inhibitory concentration: 43000 nM
For compound 4 the middle estimate is 2.6-fold (0.41 log units) above the measured one, within the range that was stated.
By their numbers in this assay, from the lowest: compound 4; then compounds 1 and 2 (each within the scatter of the next). At a limit, above all of these: compound 3.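

In this assay, the aromatic carbon two atoms from the ring nitrogen accepts a different group without loss: phenethyl in place of pent-1-yn-1-yl gives a 2.2-fold lower number from compound 1 to compound 4 (0.34 log units; beyond the scatter) and so moves toward stronger inhibition. This is the only step among the compounds shown that is printed as beyond the scatter, and it is modest; the earlier step concerned a saturated chain on a different core and ran toward weaker inhibition. Nothing measured here tells whether the gain of a six-membered aromatic ring, the loss of the triple bond or the larger group accounts for this step.

As far as these compounds go, what a benzyl or a plain phenyl group would do at this position stays open, as does whether a saturated pentyl chain would match pent-1-yn-1-yl. Also open, from the compounds shown here alone, is whether phenethyl would bring a similar step on the core of compound 2, and whether an amine or a hydroxyl group on its aromatic ring would shift the number further.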